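Moving the Chlorine Atom on a Weakly Antiproliferative Scaffold

A few compounds are considered here, and "the series" means these few. Any claim that something is new, unique, unknown or untested is made for them only; others in the source may bear on it.

Compound 3 `CC1=NN(c2cccc(Cl)c2)C(=O)C12C=CC(=O)C=C2c1cccc(C)c1` was tested in a functional assay on A549 cells (Homo sapiens) for antiproliferative activity, read by CCK-8 assay, with a stated time of 72 h (a higher number here means a weaker inhibitor, a lower number a stronger inhibitor), where compound 3 gives 20100 nM. Of the two compounds with a number, compound 3 has the higher one, but its gap to compound 1 `CC1=NN(c2ccccc2)C(=O)C12C=CC(=O)C=C2c1ccccc1`, which gives 16500 nM, lies within the scatter. Compound 2 `CC1=NN(c2ccc(Br)cc2)C(=O)C12C=CC(=O)C=C2c1ccccc1` reached only a limit of the assay, (the limit of > 100000 nM in this assay, at which 1 of the 3 values shown sits), and compound 2 gives > 100000 nM. Compound 4 `CC1=NN(c2ccc(Cl)cc2)C(=O)C12C=CC(=O)C=C2c1cccc(C)c1` differs from compound 3 by 4-chlorophenyl in place of 3-chlorophenyl on an amide-type nitrogen in a ring. Within the data shown here, the only measured step that touches this ring is an at least 6.0-fold higher number from compound 1 to compound 2 (0.78 log units; beyond the scatter), where adding a halogen to it weakened the effect. A modest weakening is therefore expected, a 2.0-fold higher number from compound 3 to compound 4 (0.30 log units; within the scatter). Compound 4 is estimated at 40000 nM, with a likely range from 15000 nM to 100000 nM.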

Compound 4, half-maximal inhibitory concentration: 38400 nM
Estimate against measurement, compound 4: 1.0-fold (0.02 log units) above; measured number inside the range.
By their numbers in this assay, from the lowest: compounds 1, 3 and 4 (each within the scatter of the next, the first and the last beyond it). At a limit, above all of these: compound 2.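

The earlier step added a halogen to this ring; this one keeps the same atoms and only moves the chlorine, from 3-chlorophenyl to 4-chlorophenyl. In this assay that move gives a 1.9-fold higher number from compound 3 to compound 4 (0.28 log units; within the scatter), so the two placements of chlorine cannot be told apart here. No available measurement bears on why these two compounds read as they do.

Still open, on these data alone, is whether a different kind of group on this ring, such as an amine or a carboxylic acid, would move the number beyond the scatter.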